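Pyrazole substituent swap at the pyridine-linked position

A few compounds are considered here, and "the series" means these few. Any claim that something is new, unique, unknown or untested is made for them only; others in the source may bear on it.

Measured in an assay on cells for inhibition of MAP kinase-interacting serine/threonine-protein kinase 1 (Homo sapiens), read by mobility shift assay, with stated times of 10 min and 60 min, in the presence of a further agent that is not named here; on this read-out higher numbers stand for weaker inhibition and lower numbers for stronger inhibition:
compound 1 `CC(C)Oc1cc(-c2cncc(-c3cnn(C(C)C)c3)c2)ccc1C(N)=O` 85 nM
compound 2 `CC(C)Oc1cc(-c2cncc(-c3cnn(C4CCOC4)c3)c2)ccc1C(N)=O` 120 nM
compound 3 `Nc1ccc(-n2cnc(Cl)c2Cl)cc1` 103000 nM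

Compound 1 gives the lowest number of the three; compound 2 sits within the scatter of it, and compound 3, built on a different core, lies far beyond it. Within the data shown here, the one step that touches the pyrazole substituent, a 1.4-fold higher number from compound 1 to compound 2 (0.15 log units; within the scatter), shows that exchanging the group on the pyrazole nitrogen leaves the read-out unchanged within the scatter.

Compound 4 `CC(C)Oc1cc(-c2cncc(-c3c[nH]nc3C3CC3)c2)ccc1C(N)=O` carries the change (3-cyclopropyl-1H-pyrazol-4-yl in place of 1-isopropyl-1H-pyrazol-4-yl on an aromatic carbon). Among the measured compounds shown here, no measured step reproduces this exact change, so the expectation leans on compound 1 and on the tolerance seen in the step to compound 2. The expected step is a 1.2-fold higher number from compound 1 to compound 4 (0.07 log units; within the scatter), that is, none beyond the scatter. Compound 4 is therefore estimated at 100 nM in this assay, ranging from 35 nM to 300 nM.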

Compound 4, half-maximal inhibitory concentration: 130 nM
The estimate for compound 4 lay 1.3-fold (0.11 log units) below the measured number; low and high end bracket the measured number.
By their numbers in this assay, from the lowest: compounds 1, 2 and 4 (each within the scatter of the next); then compound 3.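

In this assay, 3-cyclopropyl-1H-pyrazol-4-yl in place of 1-isopropyl-1H-pyrazol-4-yl gives a 1.5-fold higher number from compound 1 to compound 4 (0.18 log units; within the scatter) even though the entering group has 1 hydrogen-bond donor where the leaving group has 0 hydrogen-bond donors. Unlike the step to compound 2, this change alters the substitution of the pyrazole itself, not only the group on its nitrogen, and the read-out still stays within the scatter. Nothing measured here gives a reason for this tolerance. Going by these compounds, whether an amine, a carboxylic acid or a longer alkyl chain on the pyrazole would also stay within the scatter remains open. On these data alone, in compound 4 the cyclopropyl ring and the free pyrazole nitrogen enter together, so their separate contributions also remain open.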